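The compounds below may be only part of what the source reports. "The series", "measured", "known", "first", "only" and "open" are said of these compounds alone.

In an ADME assay on BJ cells (Homo sapiens) for cytotoxicity, read by CellTiter-Glo and resazurin assay, with a stated time of 72 h (on this read-out higher numbers stand for an effect only at larger amounts of compound and lower numbers for an effect already at smaller amounts), compound 1 `CC(C)N(Cc1cccc(OCCCCCC(=O)O)c1)C(=O)c1ccc(-c2ccoc2)cc1` gives > 26000 nM, a limit of the assay rather than a number.
In this assay compound 2 `CC(C)N(Cc1cccc(OCCCCCC(=O)O)c1)C(=O)c1ccc(-c2cccc(Oc3ccccc3)c2)cc1` gives > 18700 nM, again a limit.
In this assay compound 3 `Cc1nnc(-c2cccc(-c3ccc(C(=O)N(Cc4cccc(OCCCCCC(=O)O)c4)C(C)C)cc3)c2)o1` gives > 26000 nM, also a limit.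

Compound 3 therefore stands at the limit of > 26000 nM in this assay, at which 2 of the 3 values shown sit, while compound 2 stands at the limit of > 18700 nM in this assay, at which 1 of the 3 values shown sits. None of the three measurements gives a number, so the step that the two limits leave unreadable from compound 1 to compound 3 cannot be sized, and the same holds for a step that the two limits leave unreadable from compound 2 to compound 3. Nothing measured here shows any change in cytotoxicity that rises above the scatter.

Compound 4 `CC(C)N(Cc1cccc(OCCCCCC(=O)O)c1)C(=O)c1ccc(-c2cccc(Cl)c2)cc1` differs from compound 3 in one place: chloro in place of 5-methyl-1,3,4-oxadiazol-2-yl on an aromatic carbon. The measured steps that bear on this change are the two that lead into compound 3, and both are unreadable, so no direction or size can be drawn from them. The expected step from compound 3 to compound 4 in this assay is a step that the limit leaves unreadable from compound 3 to compound 4, no change beyond the scatter. Compound 4 is therefore estimated at 30000 nM in this assay, with a range from 10000 nM to 100000 nM, most likely again reported only as a limit.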

Compound 4, half-maximal effective concentration: > 21900 nM
Compound 4 was reported as a limit (the forecaster's own chance of this, stated with the estimate: 80%); the middle value lies beyond the limit too.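

Compound 4, like compound 1, compound 2 and compound 3, is reported in this assay only as a limit, so the steps linking compound 4 to those three cannot be read. The compounds shown leave open at what concentration any of the four affects the cells, and whether changing this one group alters that concentration.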